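This account rests on a few compounds, and the source may have more. Where it says the series, first, only, none or still open, it means among the compounds named here.

Series notes, measured in an ADME assay on H1-HeLa cells (Homo sapiens) for cytotoxicity, read by MTT assay, with a stated time of 3 days; a higher number here means that more compound is tolerated, a lower number that less compound is tolerated:

- compound 1 `CNC(=O)c1cc(Oc2ccc3c(C)c(C(=O)OC)sc3c2)ccn1`: 10800 nM
- compound 2 `CCCOC(=O)c1sc2cc(Oc3ccnc(C(=O)NC)c3)ccc2c1C`: 37400 nM

Of these two compounds, compound 2 stands highest at 37400 nM, and compound 1 lies lower at 10800 nM.

The next compound is compound 3 `CNC(=O)c1cc(Oc2ccc3c(C)c(C(=O)O)sc3c2)ccn1`, which is reached from compound 2 by hydrogen in place of propyl on an oxygen next to a carbonyl group. In words, this is hydrogen in place of propyl on an oxygen next to a carbonyl group, or propoxycarbonyl to carboxy.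

Among the compounds with values here, only one measured step bears on this change: a 3.5-fold higher number from compound 1 to compound 2 (0.54 log units; beyond the scatter). That step is modest and alters the chain on the same oxygen, but it does not replace the chain with hydrogen. Within the data shown here, its direction therefore cannot simply be carried over, and no carboxy compound has yet been measured in this assay. The size of that step serves as a guide, with wide margins on either side. A modest rise is expected, though a fall cannot be excluded. The expected change is a 2.4-fold higher number from compound 2 to compound 3 (0.38 log units; beyond the scatter). Compound 3 is estimated at 90000 nM, with an expected range from 20000 nM to 300000 nM.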

Compound 3, half-maximal cytotoxic concentration: > 100000 nM
Compound 3: only a limit was reported (the forecaster's own chance of this, stated with the estimate: 45%); middle value at least 1.1-fold (0.04 log units) away from the limit.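

In this assay, hydrogen on the oxygen next to a carbonyl group puts compound 3 at the top of the series, with an at least 2.6-fold higher number from compound 2 to compound 3 (0.42 log units; beyond the scatter) and with an at least 9.2-fold higher number from compound 1 to compound 3 (0.96 log units; beyond the scatter). Taken alone, a 3.5-fold higher number from compound 1 to compound 2 (0.54 log units; beyond the scatter) could be read as a longer chain on this oxygen going with more compound tolerated, but compound 3 goes against that reading: hydrogen, with no heavy atom, carries a higher number than either propyl or methyl. Chain length alone therefore does not order the three compounds at this position, and the free carboxy group belongs at the tolerated end of what is shown.

From the compounds shown here alone, compound 3 reads > 100000 nM, which is a limit of the assay and not a number, so the true size of both new steps stays unknown: the limit of > 100000 nM in this assay, at which 1 of the 3 values shown sits. Whether a butyl chain on this oxygen, or a primary amide in place of the carboxy group, would sit with the two chains or with hydrogen remains open, as does whether this order holds for changes elsewhere on the shared core.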